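Trading 1-benzofuran-2-yl for ethynyl on the shared core

A few compounds are considered here, and "the series" means these few. Any claim that something is new, unique, unknown or untested is made for them only; others in the source may bear on it.

Measured in a functional assay on HepG2 cells (Homo sapiens) for antiproliferative activity, read by XTT assay, with a stated time of 72 h; a higher number here means a weaker inhibitor, a lower number a stronger inhibitor:
- compound 1 `C#Cc1cn([C@@H]2O[C@H](CO)[C@@H](O)[C@H]2O)c2ncnc(SC)c12`: > 15000 nM (a limit)
- compound 2 `CN(C)c1ncnc2c1c(-c1ccoc1)cn2[C@@H]1O[C@H](CO)[C@@H](O)[C@H]1O`: 12500 nM
- compound 3 `CN(C)c1ncnc2c1c(-c1cc3ccccc3o1)cn2[C@@H]1O[C@H](CO)[C@@H](O)[C@H]1O`: > 20000 nM (a limit)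

Compound 3 gives only a limit, > 20000 nM, and no exact number. Compound 4 `C#Cc1cn([C@@H]2O[C@H](CO)[C@@H](O)[C@H]2O)c2ncnc(N(C)C)c12` carries ethynyl in place of 1-benzofuran-2-yl on an aromatic carbon. The closest measured swap at that carbon is an at least 1.6-fold higher number from compound 2 to compound 3 (0.20 log units; that floor lies within the scatter), so it shows no clear effect. Compound 1 also carries ethynyl, with a different group elsewhere on the core, and its result is a limit, > 15000 nM. In this assay only a modest drop in the number is therefore expected, possibly none beyond the scatter. The expected change is an at least 1.6-fold lower number from compound 3 to compound 4 (0.22 log units; that floor lies within the scatter). For compound 4 the estimate is 12000 nM, with an expected range from 4000 nM to 20000 nM.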

Compound 4, half-maximal inhibitory concentration: 1320 nM
Beside the measured number, compound 4's estimate is 9.1-fold (0.96 log units) above it, and the stated range ends above it.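

In this assay, ethynyl on this aromatic carbon gives a clearly lower number than either ring group, with an at least 15-fold lower number from compound 3 to compound 4 (1.18 log units; beyond the scatter) and a 9.5-fold lower number from compound 2 to compound 4 (0.98 log units; beyond the scatter). Ethynyl alone does not settle the result, as dimethylamino in place of methylsulfanyl elsewhere on the shared core gives an at least 11-fold lower number from compound 1 to compound 4 (1.05 log units; beyond the scatter). The steps starting at compound 1 and at compound 3 rest on limits, so they are floors.

As far as these compounds go, it remains open whether a propynyl chain or a nitrile on this carbon would keep the lower number. From the compounds shown here alone, whether methylamino could replace dimethylamino is also open.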